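This account rests on a few compounds, and the source may have more. Where it says the series, first, only, none or still open, it means among the compounds named here.

In a functional assay (aorta) with Rattus norvegicus as the target (on this read-out lower numbers stand for stronger inhibition and higher numbers for weaker inhibition), three compounds on a shared core have been measured. Compound 1 (`CC1(C)Oc2ccc(C#N)cc2[C@@H](/N=C(\NC#N)Nc2ccccc2)[C@@H]1O`) gives 1400 nM; 1300 nM (2 entries). Compound 2 (`CC1(C)Oc2ccc(C#N)cc2[C@@H](NC(=O)Nc2ccccc2)[C@@H]1O`) gives 800 nM, and compound 3 (`CC1(C)Oc2ccc(C#N)cc2[C@@H](NC(=O)NCc2ccccc2)[C@@H]1O`) gives 5600 nM, the higher of these two single numbers. The next candidate is compound 4 (`CC1(C)Oc2ccc(C#N)cc2[C@@H](NC(=O)c2ccccc2)[C@@H]1O`), with phenyl in place of benzylamino on a carbonyl carbon. Among the measured compounds shown here, one measured step bears on this change: a 7.0-fold higher number from compound 2 to compound 3 (0.85 log units; beyond the scatter), where a phenyl group gives way to a benzyl group. Compound 4, like compound 2, carries a phenyl group and no benzyl, so a lower number than that of compound 3 is expected in this assay, of about the size of that modest step. For the measured compounds named here, no measured step covers the loss of the amide-type nitrogen, so the expectation remains loose. The expected change is a 5.6-fold lower number from compound 3 to compound 4 (0.75 log units; beyond the scatter). For compound 4 the estimated value is 1000 nM, with an expected range from 250 nM to 4000 nM.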

Compound 4, half-maximal inhibitory concentration: 30 nM
Beside the measured number, compound 4's estimate is 33-fold (1.52 log units) above it; the measured number lies below the stated range.
By their numbers in this assay, from the lowest: compound 4; then compound 2; then compound 3.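

In this assay the carbonyl carbon proves far more sensitive to what is attached directly to it than compounds 2 and 3 could show, since both keep a nitrogen there and differ only in phenyl against benzyl. With phenyl bonded directly to the carbonyl carbon, the replacement of benzylamino gives a 190-fold lower number from compound 3 to compound 4 (2.27 log units; beyond the scatter), and the replacement of anilino, which keeps the ring and removes the nitrogen, still gives a 27-fold lower number from compound 2 to compound 4 (1.43 log units; beyond the scatter), so a large share of the change does not depend on the benzyl group. Nothing at hand accounts for the size of these steps.

The compounds shown leave open whether an aromatic ring on the carbonyl carbon is needed at all, which a methyl group or a longer chain in its place would test. They also leave open whether a phenyl group carrying a methoxy group or a chlorine, or a pyridine ring, would keep this number.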